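A few compounds are considered here, and "the series" means these few. Any claim that something is new, unique, unknown or untested is made for them only; others in the source may bear on it.

Measured compounds:
compound 1 `COc1ccc(-c2cn3ccnc3c(-c3ccc4ncn(C5CCCCC5)c4c3)n2)cc1` — 91.7%
compound 2 `O=Cc1ccc(-c2cn3ccnc3c(-c3ccc4ncn(C5CCCCC5)c4c3)n2)cc1` — 47.5%
compound 3 `Fc1ccc(-c2cn3ccnc3c(-c3ccc4ncn(C5CCCCC5)c4c3)n2)cc1` — 20.4%

All three share one core and differ only in the group on its aromatic carbon. In a functional assay on SR cells (Homo sapiens) for inhibition, read by sulforhodamine B assay, with a stated time of 48 h, tested at 10 uM (a lower number here means less inhibition, a higher number more inhibition at the concentration tested (going by the name of the read-out)), compound 1 gives the highest of the three numbers; compound 2 stands nearest to it, a number 44.2 percentage points lower from compound 1 to compound 2 (beyond the scatter), and compound 3 furthest, a number 71.3 percentage points lower from compound 1 to compound 3 (beyond the scatter). Between those two, a number 27.1 percentage points lower from compound 2 to compound 3 (beyond the scatter).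

Compound 4 `c1cn2cc(-c3ccsc3)nc(-c3ccc4ncn(C5CCCCC5)c4c3)c2n1` is not yet measured. It differs from compound 1 by thiophen-3-yl in place of 4-methoxyphenyl on an aromatic carbon. Among the measured compounds shown here, no measured step replaces the whole 4-methoxyphenyl by another ring, so none bears directly on this change. What the two steps from compound 1 do show is that the methoxy group leaving, whether formyl or fluoro enters in its place, cost a large part of the inhibition in both cases. For the measured compounds named here, the loss of that group is therefore expected to matter here as well, and a downward step is expected for compound 4, a number 46.7 percentage points lower from compound 1 to compound 4 (beyond the scatter), of a size that is uncertain because the entering thiophen-3-yl has no counterpart among compounds 2 and 3. For compound 4 the estimate is 45%, with a range from 15% to 80%.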

Compound 4, a percentage reported as inhibition, at one concentration (the size of the read-out at that concentration, not a potency): 14.3%
Compound 4: the middle estimate sits 30.7 percentage points above what was measured; measured number outside the range, below it.
By their numbers in this assay, from the lowest: compounds 4 and 3 (each within the scatter of the next); then compound 2; then compound 1.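

In this assay, exchanging the whole ring gives a number 77.4 percentage points lower from compound 1 to compound 4 (beyond the scatter), so at this position on the shared core, thiophen-3-yl does not retain the level of 4-methoxyphenyl, and all three replacements now shown fall short of compound 1. Among the replacements, the thiophen-3-yl change relative to the 4-formylphenyl compound gives a number 33.2 percentage points lower from compound 2 to compound 4 (beyond the scatter), whereas relative to the 4-fluorophenyl compound it gives a number 6.1 percentage points lower from compound 3 to compound 4 (within the scatter), which leaves those two groups indistinguishable here. No measurement is available that would account for any of these steps.

Still open, as far as these compounds go, is whether the difference follows the six-membered ring or the methoxy group, which a thiophen-3-yl carrying methoxy would help to separate. Also open, from the compounds shown here alone, is how an amine or an ethoxy group on the phenyl ring would compare with methoxy.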